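This account rests on a few compounds, and the source may have more. Where it says the series, first, only, none or still open, it means among the compounds named here.

Measured compounds in an ADME assay on WI-38 cells (Homo sapiens) for cytotoxicity, read by MTT assay, with a stated time of 72 h; a lower number here means a stronger inhibitor, a higher number a weaker inhibitor:
compound 1 `CN(C)CCn1cnnc1-c1cc(Oc2ccc(NC(=O)N/N=C/c3ccc(Cl)cc3Cl)cc2F)ccn1`, 4760 nM
compound 2 `CN(C)CCn1cnnc1-c1cc(Oc2ccc(NC(=O)N/N=C/c3ccccc3O[N+](=O)[O-])cc2F)ccn1`, 6860 nM
compound 3 `CN(C)CCn1cnnc1-c1cc(Oc2ccc(NC(=O)N/N=C/c3ccccc3)cc2F)ccn1`, "not determined" (no result reported)

Compound 3 stands nowhere on the numbers: this assay gave no single number for it, so it has no value of its own against which compound 4 `COc1cc(/C=N/NC(=O)Nc2ccc(Oc3ccnc(-c4nncn4CCN(C)C)c3)c(F)c2)ccc1O` can be set. The change from compound 3 to compound 4 is 4-hydroxy-3-methoxyphenyl in place of phenyl on a carbon with a double bond to nitrogen.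

For the measured compounds named here, the one measured step that bears on it is the step from compound 1 to compound 2, which also exchanges the aryl group on the carbon with a double bond to nitrogen and leaves the shared core untouched: a 1.4-fold higher number from compound 1 to compound 2 (0.16 log units; within the scatter). Both measured compounds therefore sit at a similar level in this assay, and the exchange of that aryl group did not move the number beyond the scatter. With only this one comparison, and no number for compound 3, the expectation for compound 4 can rest only on the level shown by compound 1 and compound 2, with no direction of step beyond the scatter assumed for the new group.

Compound 4 is therefore estimated at 5500 nM in this assay, with an expected range from 2000 nM to 16000 nM.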

Compound 4, half-maximal inhibitory concentration: 5320 nM
Estimate against measurement, compound 4: 1.0-fold (0.01 log units) above; the range from low to high includes it.
By their numbers in this assay, from the lowest: compounds 1, 4 and 2 (each within the scatter of the next).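

In this assay, a third aryl group on the carbon with a double bond to nitrogen, 4-hydroxy-3-methoxyphenyl, stays within the scatter of both earlier compounds (a 1.3-fold lower number from compound 2 to compound 4 (0.11 log units; within the scatter); a 1.1-fold higher number from compound 1 to compound 4 (0.05 log units; within the scatter)). For the compounds shown here, the earlier pair covered only 2,4-dichlorophenyl and 2-(nitrooxy)phenyl; the level now also holds for a group carrying hydroxy and methoxy, with no step among the three compounds beyond the scatter. The step from compound 3 to compound 4 cannot be read, as a plain phenyl at this position has no number in this assay to serve as a reference. No measurement is at hand that would explain why the three compounds share this level.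

Open, going by these compounds, is whether this position stays as flat with an amine or a carboxylic acid on the phenyl group, since all three measured groups are substituted phenyl groups without either. The shared core is also the same throughout, so the compounds shown cannot tell whether a longer chain on that core would shift the number in this assay or leave it at the same level.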